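Trimming One Carbon From an Amide Substituent

The source may report more compounds than this note shows. Statements on the series, on what has been measured and on what is new or still open speak of the compounds shown alone.

Of the compounds shown here, three have been measured in an assay on the whole organism (plasma, strain Sprague-Dawley) for inhibition of Dipeptidyl peptidase 4 (Rattus norvegicus), with a stated time of 6 h, at a dose of 1 mg/kg by the oral route; on this read-out higher numbers stand for more inhibition at the one dose given (going by the name of the read-out) and lower numbers for less inhibition. Compound 1 `N#C[C@@H]1CCCN1C(=O)[C@@H]1C[C@H](C(=O)N2CCCCCCC2)CN1` gives 63%. Compound 2 `CCN(CC)C(=O)[C@@H]1CN[C@H](C(=O)N2CCC[C@H]2C#N)C1` gives 43%, and compound 3 `C[C@@H]1N[C@H](C(=O)N2CCC[C@H]2C#N)C[C@@H]1C(=O)N1CCSCC1` gives 92%. Among these three, compound 2 stands lowest: its nearest neighbour is compound 1 and its furthest is compound 3, and both gaps lie beyond the usual scatter of this kind of measurement.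

Going by the values given here, only one pair of measured compounds differs in a single place: a number 20 percentage points lower from compound 1 to compound 2 (beyond the scatter). Replacing a larger group carrying a ring by a smaller open chain on the carbonyl carbon therefore cost a modest amount of inhibition.

Compound 4 `CCN(C)C(=O)[C@@H]1CN[C@H](C(=O)N2CCC[C@H]2C#N)C1` has not yet been measured. It differs from compound 2 by hydrogen in place of methyl on a saturated chain carbon bound to an amide-type nitrogen. This is again a trimming of the group attached to that carbonyl carbon, though a far smaller one than in the measured step, and that step pointed downward. A smaller drop, or none beyond the scatter, is therefore expected. Compound 4 is estimated at 37%, with a range from 20% to 56%. The expected step, a number 6 percentage points lower from compound 2 to compound 4 (within the scatter), follows the direction of a number 20 percentage points lower from compound 1 to compound 2 (beyond the scatter) but is smaller.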

Compound 4, a percentage reported as inhibition, in the whole organism at one dose (the size of the read-out at that dose, not a potency): 71%
Compound 4: the middle estimate sits 34 percentage points below what was measured; measured number outside the range, above it.
By their numbers in this assay, from the lowest: compound 2; then compounds 1 and 4 (each within the scatter of the next); then compound 3.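

In this assay, the group on this carbonyl carbon proves sensitive to a single methyl: going from diethylcarbamoyl to ethyl(methyl)carbamoyl gives a number 28 percentage points higher from compound 2 to compound 4 (beyond the scatter), so losing one carbon from the chain is enough to move the read-out beyond the scatter. The step from the eight-membered ring to the open chain of compound 4 reads a number 8 percentage points higher from compound 1 to compound 4 (within the scatter), so on this read-out the two groups cannot be told apart, and the earlier impression that a smaller group here brings less inhibition does not hold for compound 4. Among these three compounds, size alone does not set the outcome, as compound 2, whose group is smaller than that of compound 1 and larger than that of compound 4, stands lowest.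

Going by these compounds, it remains open how the read-out would respond to a dimethylamino group, a methylamino group or a longer chain such as dipropylamino in this place. Nothing at hand shows what lies behind the step from diethylamino to ethyl(methyl)amino, and a single oral dose at a single time cannot settle that.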